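Swapping chloro for bromo on the benzamide ring

A few compounds are considered here, and "the series" means these few. Any claim that something is new, unique, unknown or untested is made for them only; others in the source may bear on it.

Of the compounds shown here, three sharing one core have been measured in a functional assay on HL-60 cells (Homo sapiens) for antiproliferative activity, with a stated time of 24 h; on this read-out higher numbers stand for weaker inhibition and lower numbers for stronger inhibition. Compound 1 `NC(=O)c1c(NC(=O)c2ccccc2Cl)sc2c1CCN(C(=O)Nc1ccccc1Cl)C2` gives 12500 nM. Compound 2 `NC(=O)c1c(NC(=O)c2ccccc2Cl)sc2c1CCN(C(=S)Nc1ccccc1Br)C2` gives 9090 nM, and compound 3 `NC(=O)c1c(NC(=O)c2ccccc2Cl)sc2c1CCN(C(=S)Nc1ccc(C(F)(F)F)cc1)C2` gives 7590 nM. Compound 2 stands second highest of the three numbers; its nearest neighbour is compound 3 and its furthest is compound 1, and both of those gaps are within the scatter.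

Compound 4 `NC(=O)c1c(NC(=O)c2ccccc2Br)sc2c1CCN(C(=S)Nc1ccccc1Br)C2` has not yet been measured. It differs from compound 2 by bromo in place of chloro on an aromatic carbon. Going by the values given here, no measured pair shows this exact exchange on this ring. The two measured steps, a 1.4-fold lower number from compound 1 to compound 2 (0.14 log units; within the scatter) and a 1.2-fold lower number from compound 2 to compound 3 (0.08 log units; within the scatter), both change a different part of the molecule and both stay within the scatter, so the data give no sign that exchanging one halogen for another here would move the number in this assay beyond the scatter in either direction. The expected step is therefore a 1.0-fold lower number from compound 2 to compound 4 (0.00 log units; within the scatter), essentially none. Compound 4 is thus estimated at 9000 nM, with a range from 4500 nM to 18000 nM.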

Compound 4, half-maximal inhibitory concentration: 17600 nM
Estimate against measurement, compound 4: 2.0-fold (0.29 log units) below, within the range that was stated.
By their numbers in this assay, from the lowest: compounds 3, 2, 1 and 4 (each within the scatter of the next, the first and the last beyond it).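

In this assay, going by these compounds alone, the benzamide ring is changed directly for the first time, as the earlier steps all involved a different part of the molecule. Bromo in place of chloro on this aromatic carbon, ortho to a large group, gives a 1.9-fold higher number from compound 2 to compound 4 (0.29 log units; within the scatter), so this single exchange of one halogen for another does not separate the two compounds beyond the usual scatter. Nothing available here explains the result or links it to any property of either halogen.

This reading comes from one pair of compounds, both carrying the same 2-bromophenyl group elsewhere, so the same exchange might behave differently alongside other groups. Going by these compounds, it also remains open whether a group other than a halogen at this position, such as a methoxy group or an amine, would move the number beyond the scatter.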